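The compounds below may be only part of what the source reports. "The series", "measured", "known", "first", "only" and "open" are said of these compounds alone.

Compound 1 `C/C(=C\CC/C(C)=C/CC[C@@H]1[C@@]2(C)CCC(=O)C(C)(C)[C@H]2CC[C@@]1(C)O)CC/C=C(\C)C(=O)OCc1cn(-c2ccccc2Cl)nn1`: > 150000 nM
Compound 2 `C/C(=C\CC/C(C)=C/CC[C@@H]1[C@@]2(C)CCC(=O)C(C)(C)[C@H]2CC[C@@]1(C)O)CC/C=C(\C)C(=O)OCc1cn(-c2ccccc2C(F)(F)F)nn1`: > 150000 nM
Compound 3 `C/C(=C\CC/C(C)=C/CC[C@@H]1[C@@]2(C)CCC(=O)C(C)(C)[C@H]2CC[C@@]1(C)O)CC/C=C(\C)C(=O)OCc1cn(-c2ccc(C(C)(C)C)cc2)nn1`: 65800 nM

Three compounds share one core and differ only in the aryl group on the aromatic nitrogen of the five-membered ring with three nitrogens. For the measured compounds named here, in an ADME assay on L132 cells (Homo sapiens) for cytotoxicity, read by MTT assay, with a stated time of 48 h (a higher number here means a weaker inhibitor, a lower number a stronger inhibitor), compound 3 gives 65800 nM, the only true number among the three. For compound 1 the assay reports only a limit, > 150000 nM. For compound 2 it likewise reports only a limit, > 150000 nM. Hence a step that the two limits leave unreadable from compound 1 to compound 2, while an at least 2.2-fold lower number from compound 1 to compound 3 (0.35 log units; beyond the scatter) and an at least 2.2-fold lower number from compound 2 to compound 3 (0.35 log units; beyond the scatter); both steps run from a halogen- or trifluoromethyl-bearing phenyl to the tert-butyl one.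

Compound 4 `C/C(=C\CC/C(C)=C/CC[C@@H]1[C@@]2(C)CCC(=O)C(C)(C)[C@H]2CC[C@@]1(C)O)CC/C=C(\C)C(=O)OCc1cn(-c2cccc(Br)c2)nn1` differs from compound 3 by 3-bromophenyl in place of 4-(tert-butyl)phenyl on an aromatic nitrogen. This change runs the other way, back to a halogen-bearing phenyl, so compound 4 is expected to move back toward the limit of > 150000 nM in this assay, at which 2 of the 3 values shown sit, by about a 1.8-fold higher number from compound 3 to compound 4 (0.26 log units; within the scatter). Compound 4 is therefore estimated at 120000 nM, with a range of 45000 nM to 300000 nM.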

Compound 4, half-maximal inhibitory concentration: > 150000 nM
Compound 4 was reported as a limit (the forecaster's own chance of this, stated with the estimate: 45%); middle value at least 1.2-fold (0.09 log units) from the limit.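

Compound 4 is reported only as a limit, > 150000 nM. In this assay, the change to 3-bromophenyl gives an at least 2.2-fold higher number from compound 3 to compound 4 (0.35 log units; beyond the scatter), so a bromine-bearing phenyl group on the aromatic nitrogen joins the 2-chlorophenyl and 2-(trifluoromethyl)phenyl groups on the limit side, and among these four compounds only the 4-(tert-butyl)phenyl group of compound 3 yields a true number: the limit of > 150000 nM in this assay, at which 3 of the 4 values shown sit. The steps linking compound 1, compound 2 and compound 4 to one another cannot be read, as all three values are limits.

The compounds shown cannot separate the identity of the tert-butyl group from its place on the phenyl ring, since no group appears at two different places. They also leave open how a phenyl ring carrying an amine or a carboxylic acid would read in this assay.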